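Extending a propargylamine side chain: coumarin-based amine oxidase inhibitors

The source may hold more compounds than are shown below. What is called first, only, known or untested is meant among the compounds shown, and "the series" means these compounds.

Compound 1 `C#CCN(C)CCCOc1ccc2ccc(=O)oc2c1`: 1090 nM
Compound 2 `C#CCN(C)CCCCOc1ccc2ccc(=O)oc2c1`: 27 nM

Both compounds were tested in an assay on isolated protein for inhibition of Amine oxidase [flavin-containing] B (Homo sapiens), read by fluorescence and Amplex Red, with stated times of 15 min and 20 min; on this read-out lower numbers stand for stronger inhibition and higher numbers for weaker inhibition. Compound 1 gives the higher of the two numbers, with 1090 nM, while compound 2 gives 27 nM. Among the measured compounds shown here, the only step between them is a 40-fold lower number from compound 1 to compound 2 (1.61 log units; beyond the scatter), a change in the length of the chain that links the amine to the shared core.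

Compound 3 `C#CCN(CCCOc1ccc2ccc(=O)oc2c1)Cc1cccc(F)c1` keeps the chain of compound 1 and changes the amine itself: 3-fluorophenyl in place of hydrogen on a saturated chain carbon bound to an amine nitrogen. For the measured compounds named here, no measured step touches this part of the molecule; the step from compound 1 to compound 2 concerns the chain, not the amine, so it offers no direct guide. The expectation is therefore uncertain, and the expected step is a 4.4-fold lower number from compound 1 to compound 3 (0.64 log units; beyond the scatter) in this assay. For compound 3 the estimate in this assay is 250 nM, with a range from 30 nM to 2000 nM.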

Compound 3, half-maximal inhibitory concentration: 4440 nM
For compound 3 the middle estimate is 18-fold (1.25 log units) below the measured one; measured number above the stated range.
By their numbers in this assay, from the lowest: compound 2; then compound 1; then compound 3.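

Replacing hydrogen with 3-fluorophenyl on a saturated chain carbon bound to an amine nitrogen, which turns methyl into 3-fluorobenzyl, gives a 4.1-fold higher number from compound 1 to compound 3 (0.61 log units; beyond the scatter) in this assay. So the group on the amine matters as well as the chain length, and here the larger group weakens inhibition modestly without abolishing it. No supporting data are available to explain this loss of inhibition.

As far as these compounds go, it remains open whether the same change would have a similar effect on the longer chain of compound 2, where inhibition starts out much stronger. A single substituted group also cannot show whether the fluorine or the added ring drives the result, and a plain benzyl or a small ethyl group at this place could help separate those possibilities.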